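Chloro to Methyl: An Estimate for Compound 4

This account rests on a few compounds, and the source may have more. Where it says the series, first, only, none or still open, it means among the compounds named here.

Compound 1 `CN1CCC/C1=N\C(=O)Nc1cccc(Cl)c1`: 15 mg/kg
Compound 2 `CC(C)c1cccc(C(C)C)c1NC(=O)/N=C1\CCCN1C`: "not determined" (no result reported)
Compound 3 `CN1CCC/C1=N\C(=O)Nc1c(Br)cccc1Br`: > 25 mg/kg, a limit of the assay rather than a number

Three compounds share one core and were put through a functional assay on the whole organism with Rattus norvegicus as the target, with a stated time of 5 days; a lower number here means that less compound is needed, a higher number that more compound is needed for the effect. In this assay, among the measured compounds shown here, compound 1 gives 15 mg/kg, and this is the only full number among the three. Compound 3 returned only a limit in this assay, > 25 mg/kg, which is the case described by the limit of > 25 mg/kg in this assay, at which 1 of the 3 values shown sits. Compound 2 has no reported result in this assay, shown as "not determined" (no result reported). Because only one number exists, no measured step between two compounds can be given, and nothing shown tells how a change at the aromatic ring moves the read-out.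

Compound 4 `Cc1cccc(NC(=O)/N=C2\CCCN2C)c1` has not yet been measured. It differs from compound 1 in one place: methyl in place of chloro on an aromatic carbon. For the measured compounds named here, with no measured step to lean on, the expectation for this assay is a step of no clear direction and of a size within the usual scatter. The estimate for compound 4 in this assay is therefore 15 mg/kg, with a range from 7.5 mg/kg to 30 mg/kg. The step this estimate means is no change at the digits printed from compound 1 to compound 4 (within the scatter), expected to stay within the scatter.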

Compound 4, minimum effective dose: 25 mg/kg
For compound 4 the middle estimate is 1.7-fold (0.22 log units) below the measured one; the measured number falls inside the stated range.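

This is the first measured step among these compounds, and it gives a first reading of how a change on the aromatic ring moves the read-out. In this assay, methyl in place of chloro on an aromatic carbon, meta to a large group, gives a 1.7-fold higher number from compound 1 to compound 4 (0.22 log units; within the scatter), so for this one pair the swap of one heavy atom for another leaves the two compounds indistinguishable in dose. Both groups at this place give a full number, but nothing shown explains why the swap leaves the dose within the scatter.

A single pair cannot show whether this flat result is a feature of the position or only of these two similar-sized groups, and steps involving compound 2 and compound 3 cannot be read. Going by these compounds, a group of a different kind on the same aromatic carbon, such as an amine, a carboxylic acid or a longer chain, could test whether the dose in this assay moves beyond the scatter, and the other carbons of the ring remain open in the same way.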